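The compounds below may be only part of what the source reports. "The series", "measured", "known", "first", "only" and "open" are said of these compounds alone.

Measured compounds:
compound 1 `CCC1(CCCCN2CCN(c3ccc(Cl)cc3)CC2)C(=O)Nc2ccccc21`: in a functional assay on the whole organism (strain Wistar) with Rattus norvegicus as the target, with a stated time of 30 min (on this read-out lower numbers stand for an effect already at smaller amounts and higher numbers for an effect only at larger amounts of compound), compound 1 gives 10 mg/kg
compound 2 `CCC1(CCCCN2CCN(c3ccc(F)cc3)CC2)C(=O)Nc2ccccc21`: in this assay compound 2 gives 10 mg/kg

Compound 2 stands level with compound 1 on the numbers shown; the only measured step, no change at the digits printed from compound 1 to compound 2 (within the scatter), is within the scatter, so nothing separates the two on this read-out.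

Compound 3 `CCC1(CCCCN2CCN(c3ccc(Cl)c(Cl)c3)CC2)C(=O)Nc2ccccc21` differs from compound 2 by 3,4-dichlorophenyl in place of 4-fluorophenyl on an amine nitrogen in a ring. For the measured compounds named here, the measured step from compound 1 to compound 2 bears on this only in part: it shows that exchanging one halogen for another on that aromatic ring left the minimum effective dose unchanged, but no measured pair covers the addition of a second chlorine to the ring. The expectation is therefore no step beyond the scatter, with the range widened to allow for the untested second chlorine.

For compound 3 the minimum effective dose is expected at 10 mg/kg, with a range from 3 mg/kg to 30 mg/kg. This estimate means a step of no change at the digits printed from compound 2 to compound 3 (within the scatter), expected to be flat because no change at the digits printed from compound 1 to compound 2 (within the scatter) showed no change.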

Compound 3, minimum effective dose: > 20 mg/kg
Compound 3: no number, only a limit; the forecaster's own chance of this, stated with the estimate: 15%; at least 2.0-fold (0.30 log units) between middle value and limit.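

In this assay compound 3 carries a limit and not a number: the limit of > 20 mg/kg in this assay, at which 1 of the 3 values shown sits.

On the amine nitrogen in the ring, 3,4-dichlorophenyl in place of 4-fluorophenyl gives an at least 2.0-fold higher number from compound 2 to compound 3 (0.30 log units; that floor lies within the scatter), and chloro in place of hydrogen on an aromatic carbon gives an at least 2.0-fold higher number from compound 1 to compound 3 (0.30 log units; that floor lies within the scatter). Both steps are floors and not sizes, so the result does not establish a real separation of compound 3 from either earlier compound, but it does change what can be said about this position. The exchange of one halogen for another, no change at the digits printed from compound 1 to compound 2 (within the scatter), gave a level result, whereas the second chlorine on the aromatic ring gives the first result at this position that is open-ended towards larger doses.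

Going by these compounds, how far the minimum effective dose of compound 3 lies past its limit stays open, so the size of the effect of the added chloro cannot be read. Also open, on these data alone, is whether a plain phenyl on the same amine nitrogen, or a methoxy or trifluoromethyl group on that aromatic ring, would stay level with compound 1 and compound 2 or follow compound 3.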